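Swapping the pendant aryl on a trimethoxyphenyl-benzimidazole core

The source may report more compounds than this note shows. Statements on the series, on what has been measured and on what is new or still open speak of the compounds shown alone.

Measured so far:
compound 1, `COc1cc(-n2cnc3ccc(-c4ccc(C(C)=O)cc4)cc32)cc(OC)c1OC`: 2510 nM
compound 2, `COc1cc(-n2cnc3ccc(-c4ccc(C)cc4F)cc32)cc(OC)c1OC`: > 10000 nM
compound 3, `COc1cc(-n2cnc3ccc(-c4cc(F)ccc4F)cc32)cc(OC)c1OC`: 7940 nM

Of the compounds shown here, three sharing one core have been tested in a functional assay on A549 cells (Homo sapiens) for antiproliferative activity, read by MTT assay, with a stated time of 72 h; a higher number here means a weaker inhibitor, a lower number a stronger inhibitor. Compound 1 gives 2510 nM. For compound 2 the assay reports only a limit, > 10000 nM, not a number. Compound 3 gives 7940 nM, which is the highest of the two numbers, and its nearest neighbour is compound 1 by a 3.2-fold higher number from compound 1 to compound 3 (0.50 log units; beyond the scatter). The change from compound 1 to compound 2 went the same way, an at least 3.9-fold higher number from compound 1 to compound 2 (0.60 log units; beyond the scatter), while compound 2 and compound 3 differ by an at least 1.2-fold lower number from compound 2 to compound 3 (0.10 log units; that floor lies within the scatter).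

The next compound, compound 4, `COc1cc(-n2cnc3ccc(-c4cccc(Cl)c4)cc32)cc(OC)c1OC`, differs from compound 3 by 3-chlorophenyl in place of 2,5-difluorophenyl on an aromatic carbon. Among the compounds with values here, the steps that bear on it are those from compound 1 to the two halogenated phenyls, both of which weakened the compound, and the comparison of compound 2 with compound 3, which showed no difference beyond the scatter. A halogenated phenyl without the acetyl group has so far given only weak inhibition, so for compound 4 a step of a 1.0-fold higher number from compound 3 to compound 4 (0.00 log units; within the scatter) is expected, that is, no change beyond the scatter. Compound 4 is therefore estimated at 8000 nM, with a range from 3000 nM to 20000 nM.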

Compound 4, half-maximal inhibitory concentration: 7050 nM
For compound 4 the middle estimate is 1.1-fold (0.05 log units) above the measured one, within the range that was stated.
By their numbers in this assay, from the lowest: compound 1; then compounds 4 and 3 (each within the scatter of the next). At a limit, above all of these: compound 2.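

Replacing 2,5-difluorophenyl with 3-chlorophenyl on the shared core alters both the halogen and the pattern of substitution, yet in this assay it gives a 1.1-fold lower number from compound 3 to compound 4 (0.05 log units; within the scatter), so this pair shows no sensitivity to that exchange. Against the 4-acetylphenyl of compound 1, the new group gives a 2.8-fold higher number from compound 1 to compound 4 (0.45 log units; beyond the scatter), which extends the loss seen with the fluorinated phenyl of compound 3 to a chlorinated phenyl. Within the data shown here, the remaining comparison rests on a limit and not on a number, and it reads an at least 1.4-fold lower number from compound 2 to compound 4 (0.15 log units; that floor lies within the scatter), so it sets no order for that pair.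

Compound 1 alone carries a carbonyl on the pendant phenyl, and compound 1 gives 2510 nM. The compounds shown do not tell whether a carboxylic acid, an amide or a nitrile there would match or improve on that result. They also leave open how an amine on the phenyl or a pyridyl in its place would compare, and whether chlorine and fluorine would still give matching results if each stood at the same place on the ring.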